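A bromophenyl group replaces a dimethoxyphenyl group

The source may report more compounds than this note shows. Statements on the series, on what has been measured and on what is new or still open speak of the compounds shown alone.

Of the compounds shown here, three sharing one core have been tested in a functional assay on PC-3 cells (Homo sapiens) for cytotoxicity, read by MTT assay, with a stated time of 48 h (a lower number here means a stronger inhibitor, a higher number a weaker inhibitor), and they differ only in one aromatic group. Compound 1 `Cc1cccc(/C=C/[C@](C)(O)CC[C@@H]2[C@@]3(C)CCCC(C)(C)[C@@H]3CC[C@@]2(C)O)c1C` gives 3500 nM and compound 3 `COc1cccc(/C=C/[C@](C)(O)CC[C@@H]2[C@@]3(C)CCCC(C)(C)[C@@H]3CC[C@@]2(C)O)c1OC` gives 2900 nM. Between these two lies a 1.2-fold lower number from compound 1 to compound 3 (0.08 log units; within the scatter), so they count as equal. Compound 2 `CC1(C)CCC[C@]2(C)[C@@H](CC[C@@](C)(O)/C=C/c3ccc(Cl)nc3)[C@](C)(O)CC[C@@H]12` gives 275 nM, which leaves compound 3 on the weak side of this small set, with an 11-fold higher number from compound 2 to compound 3 (1.02 log units; beyond the scatter).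

The next compound is compound 4 `CC1(C)CCC[C@]2(C)[C@@H](CC[C@@](C)(O)/C=C/c3ccc(Br)cc3)[C@](C)(O)CC[C@@H]12`, where 4-bromophenyl sits in place of 2,3-dimethoxyphenyl on a double-bonded chain carbon bound to a double-bonded chain carbon: 4-bromophenyl in place of 2,3-dimethoxyphenyl on a double-bonded chain carbon bound to a double-bonded chain carbon.

Among the compounds with values here, no tested compound carries 4-bromophenyl, so the guidance is indirect. The exchange of one substituted phenyl group for another gave only a 1.2-fold lower number from compound 1 to compound 3 (0.08 log units; within the scatter), which argues for a small change. Within the data shown here, the only large changes involve the 6-chloropyridin-3-yl group of compound 2, as in a 13-fold lower number from compound 1 to compound 2 (1.10 log units; beyond the scatter). Compound 4 shares a halogen with compound 2 but keeps a ring of carbon only, like compound 1 and compound 3. A partial move is therefore expected, and the expected change is a 2.6-fold lower number from compound 3 to compound 4 (0.42 log units; beyond the scatter). For compound 4 the estimated value is 1100 nM, with an expected range from 300 nM to 3500 nM.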

Compound 4, half-maximal inhibitory concentration: 41300 nM
Beside the measured number, compound 4's estimate is 38-fold (1.57 log units) below it, outside the stated range (above it).
By their numbers in this assay, from the lowest: compound 2; then compounds 3 and 1 (each within the scatter of the next); then compound 4.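

In this assay, this position proves far more demanding among rings of carbon only than compound 1 and compound 3 suggested: there is a 14-fold higher number from compound 3 to compound 4 (1.15 log units; beyond the scatter) and also a 12-fold higher number from compound 1 to compound 4 (1.07 log units; beyond the scatter), so exchanging one substituted phenyl group for another is not always a neutral move. A halogen on the ring is not enough to bring the number down, since a 150-fold higher number from compound 2 to compound 4 (2.18 log units; beyond the scatter) separates the two halogen-bearing compounds and puts them at opposite ends of this set, with compound 2 the strongest and compound 4 the weakest. No measurement at hand accounts for how far 4-bromophenyl stands from the other groups at this place.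

Only 4-bromophenyl carries bromine here, so these compounds cannot separate the contribution of the bromine from that of the ring's substitution pattern, nor show whether the chlorine or the ring nitrogen of 6-chloropyridin-3-yl matters more. Also open, from the compounds shown here alone, is how an unsubstituted phenyl ring, 4-chlorophenyl or a phenyl ring carrying an amine or a carboxylic acid would compare on the same chain carbon.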